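From cyclohexylamino to hexylsulfanyl on the shared core

This account rests on a few compounds, and the source may have more. Where it says the series, first, only, none or still open, it means among the compounds named here.

Values in an ADME assay on MOLT-3 cells (Homo sapiens) for cytotoxicity, with a stated time of 7 days; on this read-out lower numbers stand for higher toxicity in this test and higher numbers for lower toxicity in this test:
- compound 1 `Nc1nc(OCc2ccccc2)c2ncn(/C=C3/CC3(CO)CO)c2n1`: > 20000 nM (a limit, not a number)
- compound 2 `CCCSc1nc(N)nc2c1ncn2/C=C1/CC1(CO)CO`: > 20000 nM (a limit, not a number)
- compound 3 `Nc1nc(NC2CCCCC2)c2ncn(/C=C3/CC3(CO)CO)c2n1`: "not determined" (no result reported)

Compound 3 thus offers no number from which to start. Compound 4 `CCCCCCSc1nc(N)nc2c1ncn2/C=C1/CC1(CO)CO` differs from it by hexylsulfanyl in place of cyclohexylamino on an aromatic carbon, with hexylsulfanyl in place of cyclohexylamino on an aromatic carbon. The nearest measured change, a step that the two limits leave unreadable from compound 1 to compound 2, has no readable size, and the remaining evidence is the limit of > 20000 nM in this assay, at which 2 of the 3 values shown sit. No size or direction of step can therefore be expected in this assay, only a likely level. Compound 2, which carries propylsulfanyl, gives > 20000 nM, and this is a limit. For compound 4 the expected value is 20000 nM, estimated to lie between 5000 nM and 40000 nM.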

Compound 4, half-maximal cytotoxic concentration: > 20000 nM
Compound 4: no number, only a limit; the forecaster's own chance of this, stated with the estimate: 65%; the middle value lies on the limit itself.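

In this assay, going by these compounds alone, compound 4 gives > 20000 nM, which is a limit and not a number, so no step to it from compound 1 or compound 2 can be read. The compounds shown leave open whether any of these groups on the shared core gives a numerical value in this assay.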